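The source may hold more compounds than are shown below. What is called first, only, known or untested is meant among the compounds shown, and "the series" means these compounds.

Series notes. Compound 1 `Cc1cccc(-n2nncc2CN2C(=O)C3(C(C#N)=C(N)Oc4c3c3nc5ccccc5nc3c3ccccc43)c3ccccc32)c1` carries a 3-methylphenyl on an aromatic nitrogen of the shared core. In a functional assay on HCT-116 cells (Homo sapiens) for antiproliferative activity, read by MTT assay, with a stated time of 48 h (on this read-out lower numbers stand for stronger inhibition and higher numbers for weaker inhibition), compound 1 gives > 50000 nM, which is a limit of the assay and not a number. Compound 2 `N#CC1=C(N)Oc2c(c3nc4ccccc4nc3c3ccccc23)C12C(=O)N(Cc1cnnn1-c1cccc(Br)c1)c1ccccc12` has bromo in place of methyl on an aromatic carbon. In this assay compound 2 gives > 50000 nM, again a limit rather than a number. Compound 3 `N#CC1=C(N)Oc2c(c3nc4ccccc4nc3c3ccccc23)C12C(=O)N(Cc1cnnn1-c1ccc(N)cc1)c1ccccc12` carries a 4-aminophenyl on the aromatic nitrogen instead. In this assay, for the measured compounds named here, compound 3 gives 45200 nM, the only number in the set. Compounds 1 and 2 both rest at the limit of > 50000 nM in this assay, at which 2 of the 3 values shown sit. The steps of an at least 1.1-fold lower number from compound 1 to compound 3 (0.04 log units; that floor lies within the scatter) and an at least 1.1-fold lower number from compound 2 to compound 3 (0.04 log units; that floor lies within the scatter) are read against that limit and stay within the scatter, so neither aryl swap is seen to move the number. Compound 4 `N#CC1=C(N)Oc2c(c3nc4ccccc4nc3c3ccccc23)C12C(=O)N(Cc1cnnn1-c1cccc(S(N)(=O)=O)c1)c1ccccc12` takes the change (3-sulfamoylphenyl in place of 4-aminophenyl on an aromatic nitrogen). The two measured steps bear on it only loosely, both showing an aryl change on the same nitrogen leaving the read-out about where it stands. The step of a 1.3-fold higher number from compound 3 to compound 4 (0.12 log units; within the scatter) is therefore expected to be small, in either direction, and compound 4 is estimated at 60000 nM, within a range from 25000 nM to 150000 nM, with a fair chance that only a limit is returned.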

Compound 4, half-maximal inhibitory concentration: 11300 nM
For compound 4 the middle estimate is 5.3-fold (0.73 log units) above the measured one; the whole stated range lies above it.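

In this assay the aryl group on the aromatic nitrogen proves able to move the number: 3-sulfamoylphenyl in place of 4-aminophenyl gives a 4.0-fold lower number from compound 3 to compound 4 (0.60 log units; beyond the scatter). Sulfamoyl in place of bromo gives an at least 4.4-fold lower number from compound 2 to compound 4 (0.64 log units; beyond the scatter), and sulfamoyl in place of methyl gives an at least 4.4-fold lower number from compound 1 to compound 4 (0.64 log units; beyond the scatter), two floors that are read against a limit of the assay and not against a number: the limit of > 50000 nM in this assay, at which 2 of the 4 values shown sit.
With all three steps beyond the scatter, compound 4 is the most potent of the four compounds shown.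

On these data alone, the step from the 4-aminophenyl compound changes both the group and its place on the phenyl ring, so the share of each in that step stays open. As far as these compounds go, whether the sulfamoyl group itself is required also stays open, and a carboxylic acid or a methylsulfonyl group on the same phenyl ring would bear on that.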